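Methyl to ethyl: the step from compound 2

The compounds below may be only part of what the source reports. "The series", "measured", "known", "first", "only" and "open" are said of these compounds alone.

Compound 1 `CC(=O)N1CCN(C(=O)[C@@H]2CC[C@@H](C)N2C(=O)C2=C(C(C)C)N3C(=N[C@@](C)(c4ccc(Cl)cc4)[C@H]3c3ccc(Cl)cc3)S2)CC1`: 13%
Compound 2 `CC(=O)N1CCN(C(=O)[C@@H]2CC[C@@H](C)N2C(=O)C2=C(C(C)C)N3C(=N[C@@](C)(c4ccc(Cl)cc4)[C@H]3c3ccc(Cl)cc3)S2)C[C@@H]1C`: 65%

In an ADME assay on microsomes from liver (Mus musculus) for metabolic stability, read by LC-MS, with a stated time of 30 min, tested at 1 uM (a higher number here means that more of the compound is left, a lower number that less of the compound is left), compound 2 holds the higher of the two numbers, at 65%. Compound 3 `CC[C@@H]1CC[C@@H](C(=O)N2CCN(C(C)=O)[C@@H](C)C2)N1C(=O)C1=C(C(C)C)N2C(=N[C@@](C)(c3ccc(Cl)cc3)[C@H]2c2ccc(Cl)cc2)S1` differs from it by one change: methyl in place of hydrogen on a saturated chain carbon bound to a saturated ring carbon. For the measured compounds named here, only one measured step bears on this, the large a number 52 percentage points higher from compound 1 to compound 2 (beyond the scatter), and that methyl stood on a saturated ring carbon instead, so it guides only loosely. Going by the values given here, no step at this place has been measured. A moderate fall is expected, a number 15 percentage points lower from compound 2 to compound 3 (beyond the scatter). Compound 3 is estimated at 50%, within a range of 30% to 70%.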

Compound 3, percent of the compound remaining: 54%
The estimate for compound 3 lay 4 percentage points below the measured number; low and high end bracket the measured number.
By their numbers in this assay, from the lowest: compound 1; then compound 3; then compound 2.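

In this assay the change from methyl to ethyl gives a number 11 percentage points lower from compound 2 to compound 3 (beyond the scatter), so this position does respond to one added carbon. That step is much smaller than a number 52 percentage points higher from compound 1 to compound 2 (beyond the scatter), which came from a methyl at a different place, on a saturated ring carbon. No measurement shown explains the fall at this position.

On these data alone, whether a propyl chain, an amine or a carboxylic acid at this place would raise or lower the number stays open. So does whether the change from methyl to ethyl would act the same way in compound 1.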